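A few compounds are considered here, and "the series" means these few. Any claim that something is new, unique, unknown or untested is made for them only; others in the source may bear on it.

Working notes on the series. Compound 1 `COc1ccc(OC[C@@H]2C[C@H]3C[C@H]3N2)cn1` and compound 2 `COc1ccc(OC[C@@H]2C[C@@H]3C[C@@H]3N2)cn1` have the same atoms and bonds and differ only in configuration as drawn. In an assay on CHO-K1 cells for displacement of a labelled ligand from Neuronal acetylcholine receptor; alpha4/beta2 (Homo sapiens), read by scintillation counting (a higher number here means a weaker inhibitor, a lower number a stronger inhibitor), compound 1 gives only a limit, > 10000 nM. In this assay compound 2 gives 4.7 nM, the lowest of the two numbers shown. Going by the values given here, compound 3 `C=Cc1nnc(-c2cncc(OC[C@@H]3C[C@H]4C[C@H]4N3)c2)o1` gives 2660 nM in this assay; no single-point step between compound 3 and compound 2 is defined, so only the two values stand side by side. Among the compounds with values here, the one measured step is an at least 2100-fold lower number from compound 1 to compound 2 (3.32 log units; beyond the scatter), a large one; it rests on the fact that compounds 1 and 2 differ only in the configuration as drawn and is bounded by the limit of > 10000 nM in this assay, at which 1 of the 3 values shown sits.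

Compound 4 `Fc1ccc(OC[C@@H]2C[C@@H]3C[C@@H]3N2)cn1` differs from compound 2 by fluoro in place of methoxy on an aromatic carbon. Within the data shown here, no measured step in this set changes a substituent; the configuration step from compound 1 to compound 2 does not bear on a swap of this kind. With nothing to carry over, only a modest step is expected in this assay, most likely towards a somewhat higher number, and it may well lie within the scatter. Compound 4 is therefore estimated at 9 nM in this assay, with a range from 2.5 nM to 40 nM. The expected step is a 1.9-fold higher number from compound 2 to compound 4 (0.28 log units; within the scatter).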

Compound 4, inhibition constant: 1.2 nM
Estimate against measurement, compound 4: 7.5-fold (0.88 log units) above, outside the stated range (below it).
By their numbers in this assay, from the lowest: compound 4; then compound 2; then compound 3. At a limit, above all of these: compound 1.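

Fluoro in place of methoxy on the aromatic carbon next to the ring nitrogen gives a 3.9-fold lower number from compound 2 to compound 4 (0.59 log units; beyond the scatter) in this assay, the first substituent change that can be read in the series. With the configuration of compound 2 held fixed, a low number at this position therefore does not depend on methoxy, since fluoro, counted with no hydrogen-bond acceptor, also gives one. No measurement shown here gives a reason for this step.

As far as these compounds go, whether other groups at this position, such as chloro, an amine or a nitrile, follow fluoro or methoxy stays open, and a single swap sets no trend. Also open, from the compounds shown here alone, is whether fluoro gives a similar step on the core in the configuration drawn for compound 1.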